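Alkynyl aryl variation on the shared core: growth inhibition

This account rests on a few compounds, and the source may have more. Where it says the series, first, only, none or still open, it means among the compounds named here.

Measured so far:
Compound 1, `COC(=O)c1sc2cc(C#Cc3cccc(N)c3)cnc2c1N`, in a functional assay on A375-C5 cells (Homo sapiens) for inhibition, read by sulforhodamine B assay, with a stated time of 48 h (on this read-out higher numbers stand for weaker inhibition of growth and lower numbers for stronger inhibition of growth), gives 11600 nM.
Compound 2, `COC(=O)c1sc2cc(C#Cc3ccccc3F)cnc2c1N`, in this assay reaches only a limit of the assay, > 150000 nM.
Compound 3, `COC(=O)c1sc2cc(C#Cc3ccccc3OC)cnc2c1N`, in this assay reaches only a limit of the assay, > 47300 nM.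

Compound 1 thus stands as the only number shown; the other two values are limits. Exchanging 3-aminophenyl on the triple-bonded carbon for 2-fluorophenyl gives an at least 12-fold higher number from compound 1 to compound 2 (1.11 log units; beyond the scatter), and for 2-methoxyphenyl an at least 4.0-fold higher number from compound 1 to compound 3 (0.61 log units; beyond the scatter). The step between those two limits is a step that the two limits leave unreadable from compound 2 to compound 3.

Compound 4, `COC(=O)c1sc2cc(C#Cc3ccc(F)cc3)cnc2c1N`, is not yet measured in this assay. It differs from compound 1 in one place: 4-fluorophenyl in place of 3-aminophenyl on a triple-bonded carbon. Both measured steps away from 3-aminophenyl raised the number beyond the scatter, and compound 4 likewise gives up the amino group, so a rise beyond the scatter is expected here as well, of a size between those two steps. Compound 4 is therefore estimated at 50000 nM, expected within 15000 nM to 200000 nM, which means an expected step of a 4.3-fold higher number from compound 1 to compound 4 (0.63 log units; beyond the scatter), with a real chance that only a limit is reported.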

Compound 4, concentration for 50% growth inhibition: 48400 nM
Compound 4: middle estimate off by 1.0-fold (0.01 log units), on the high side; low and high end bracket the measured number.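

Going by these compounds alone, compound 4 gives the first full number for a group without the amino function at this triple-bonded carbon: in this assay, 4-fluorophenyl in place of 3-aminophenyl gives a 4.2-fold higher number from compound 1 to compound 4 (0.62 log units; beyond the scatter), so the cost of this exchange now has a readable size. The two fluorophenyl groups also differ, with an at least 3.0-fold lower number from compound 2 to compound 4 (0.49 log units; beyond the scatter), which shows that the place of the fluoro group on the phenyl ring changes the read-out. The value of compound 2 in that step is a limit of the assay, not a number: the limit of > 150000 nM in this assay, at which 1 of the 4 values shown sits.

The step from compound 3 to compound 4 cannot be read, because compound 3 also holds only a limit: the limit of > 47300 nM in this assay, at which 1 of the 4 values shown sits. Open is whether 4-aminophenyl or 2-aminophenyl would match or improve on compound 1, and what a carboxylic acid on the phenyl ring would do.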